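The source may report more compounds than this note shows. Statements on the series, on what has been measured and on what is new or still open speak of the compounds shown alone.

Measured so far: compound 1, `COc1ccc(-c2cc3ccccc3nc2/C=C/C(=O)c2ccc(N)cc2)cc1`, gives 7510 nM in a functional assay on MDA-MB-231 cells (Homo sapiens) for antiproliferative activity, read by XTT assay, with a stated time of 72 h; on this read-out lower numbers stand for stronger inhibition and higher numbers for weaker inhibition; compound 2, `COc1ccc(-c2cc3ccccc3nc2/C=C/C(=O)c2ccc(Br)s2)cc1`, gives < 100 nM in this assay.

The value of compound 2 is not a number but a limit of this assay; it is described by the limit of < 100 nM in this assay, at which 1 of the 2 values shown sits. Within the data shown here, compound 2 therefore stands at the strong end of the two values shown, with only the step of an at least 75-fold lower number from compound 1 to compound 2 (1.87 log units; beyond the scatter) telling how far it lies from compound 1.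

Compound 3, `COc1ccc(-c2cc3ccccc3nc2/C=C/C(=O)c2cnc(N)nc2C)cc1`, differs from compound 2 by 2-amino-4-methylpyrimidin-5-yl in place of 5-bromothiophen-2-yl on a carbonyl carbon. Among the measured compounds shown here, the only measured step that bears on this place is the one from compound 1 to compound 2, and it was large: an at least 75-fold lower number from compound 1 to compound 2 (1.87 log units; beyond the scatter). That step shows that this position is sensitive to what is attached to the carbonyl, and that a ring without an amino group gave the stronger result. Since the new group in compound 3 brings back an amino group, a step toward a higher number, beyond the scatter, is expected in this assay: an at least 20-fold higher number from compound 2 to compound 3 (1.30 log units; beyond the scatter). Compound 3 is estimated at 2000 nM, with a range from 300 nM to 15000 nM.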

Compound 3, half-maximal inhibitory concentration: > 10000 nM
Compound 3 ended at the assay's limit (the forecaster's own chance of this, stated with the estimate: 15%); middle value at least 5.0-fold (0.69 log units) away from the limit.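

Compound 3 sits at the weak end of this assay, with a value that is a limit of the assay and not a number: the limit of > 10000 nM in this assay, at which 1 of the 3 values shown sits. Putting 2-amino-4-methylpyrimidin-5-yl in place of 5-bromothiophen-2-yl on the carbonyl carbon gives an at least 100-fold higher number from compound 2 to compound 3 (2.00 log units; beyond the scatter), so a second ring carrying an amino group, of a different kind from the 4-aminophenyl of compound 1, also lies far from the bromothiophene result. Replacing 4-aminophenyl with the same pyrimidine gives an at least 1.3-fold higher number from compound 1 to compound 3 (0.12 log units; that floor lies within the scatter), and with that floor inside the scatter, the data place neither of these two amino-bearing compounds firmly ahead of the other.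

As far as these compounds go, the three groups differ in several features at once, so it remains open whether the amino group, the ring type or the bromine accounts for the gap, a question that a plain phenyl ring or a thiophene without bromine would help to separate. How strong compound 2 really is also stays open, with its value being a limit of the assay as well: the limit of < 100 nM in this assay, at which 1 of the 3 values shown sits.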